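This account rests on a few compounds, and the source may have more. Where it says the series, first, only, none or still open, it means among the compounds named here.

Measured in an ADME assay on Vero cells (Chlorocebus sabaeus) for cytotoxicity, read by neutral red uptake; on this read-out higher numbers stand for lower toxicity in this test and lower numbers for higher toxicity in this test:
- compound 1 `CC1(C)CC(=O)C(=C/C=C/c2ccccc2)C(=O)C1`: > 18.7 uM (a limit)
- compound 2 `COc1ccc(/C=C/C=C2C(=O)CCCC2=O)cc1`: > 18.6 uM (a limit)

Compound 2 has only a limit in this assay, namely > 18.6 uM. Compound 1 likewise has only a limit, > 18.7 uM. Among the compounds with values here, the series therefore offers no numerical value so far, and no measured step between compounds that differ in one place.

Compound 3 `COc1ccc(/C=C/C=C2C(=O)CC(c3ccccc3)CC2=O)cc1` is compound 2 with phenyl in place of hydrogen on a saturated ring carbon of the six-membered non-aromatic ring of carbon only: phenyl in place of hydrogen on a saturated ring carbon. Within the data shown here, with no measured step to size this change, little or no shift beyond the usual scatter is expected, and any movement is expected toward lower numbers. The estimated change is an at least 1.1-fold lower number from compound 2 to compound 3 (0.06 log units; that floor lies within the scatter). The estimate for compound 3 is 16 uM, with an expected range of 6 uM to 30 uM.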

Compound 3, half-maximal toxic concentration: > 14.3 uM
Compound 3: only a limit was reported (the forecaster's own chance of this, stated with the estimate: 60%); the middle value lies beyond the limit too.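

In this assay compound 3 gives only a limit, > 14.3 uM. Within the data shown here, compound 2 also gives only a limit, > 18.6 uM, so no step from compound 2 to compound 3 can be read. Open remains the actual half-maximal toxic concentration of every compound shown, and whether phenyl in place of hydrogen on a saturated ring carbon shifts it.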